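Removing the Methyl from the 4-Methylbenzyl Group

This account rests on a few compounds, and the source may have more. Where it says the series, first, only, none or still open, it means among the compounds named here.

Among the compounds with values here, in a functional assay on A549 cells (Homo sapiens) for antiproliferative activity, read by MTT assay, with a stated time of 48 h (on this read-out lower numbers stand for stronger inhibition and higher numbers for weaker inhibition), compound 2 `Cc1ccc(CN2C(=O)N(c3ccc(Cl)cc3)C(=O)C2CCC(=O)Nc2ccc(C(=O)NO)cc2)cc1` gives 790 nM, the lower of the two numbers measured so far, while compound 1 `O=C(CCC1C(=O)N(c2ccc(Cl)cc2)C(=O)N1Cc1ccc(Br)cc1)Nc1ccc(C(=O)NO)cc1` gives 5860 nM. Compound 3 `O=C(CCC1C(=O)N(c2ccc(Cl)cc2)C(=O)N1Cc1ccccc1)Nc1ccc(C(=O)NO)cc1` has hydrogen in place of methyl on an aromatic carbon, para to a large group (hydrogen in place of methyl on an aromatic carbon). Within the data shown here, the only measured step that bears on this change is a 7.4-fold lower number from compound 1 to compound 2 (0.87 log units; beyond the scatter), a modest step with methyl in place of bromo on an aromatic carbon. Among the measured compounds shown here, that single step shows that this substituent can matter, but no compound with hydrogen there has yet been measured. A modest move to a higher number in this assay is therefore expected, smaller than the step measured between compound 1 and compound 2. The expected change is a 2.3-fold higher number from compound 2 to compound 3 (0.36 log units; beyond the scatter). Compound 3 is estimated at 1800 nM, with an expected range of 600 nM to 5000 nM.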

Compound 3, half-maximal inhibitory concentration: 9450 nM
The estimate for compound 3 lay 5.3-fold (0.72 log units) below the measured number; the whole stated range lies below it.
By their numbers in this assay, from the lowest: compound 2; then compounds 1 and 3 (each within the scatter of the next).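

Compound 3 shows that the gain seen with methyl was not simply a matter of losing the bromo: in this assay, taking the methyl away gives a 12-fold higher number from compound 2 to compound 3 (1.08 log units; beyond the scatter), a large step. Hydrogen and bromo on this aromatic carbon cannot be told apart, since a 1.6-fold higher number from compound 1 to compound 3 (0.21 log units; within the scatter) is within the scatter. Among these three compounds, then, only the 4-methylbenzyl compound stands apart, and nothing available accounts for this.

The compounds shown leave open whether the benefit belongs to methyl alone or extends to other groups in this place, such as ethyl or methoxy. They also leave open whether chloro or fluoro would stay level with bromo and hydrogen or come closer to compound 2.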